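The source may report more compounds than this note shows. Statements on the series, on what has been measured and on what is new or still open speak of the compounds shown alone.

Working notes on the series. Within the data shown here, compound 1 `CC[C@H]1OC(=O)O[C@@]1(C)[C@@H]1OC(=O)[C@H](C)C(=O)[C@H](C)[C@@H](O[C@@H]2O[C@H](C)C[C@H](N(C)C)[C@H]2O)[C@@]2(C)C[C@@H](C)[C@H](O2)[C@@H]1C` gives 26.3 uM in a functional assay on THP-1 cells (Homo sapiens), read by MTT assay, with a stated time of 4 days (on this read-out lower numbers stand for an effect already at smaller amounts and higher numbers for an effect only at larger amounts of compound), the only plain number in the set. Among the measured compounds shown here, compound 2 `CC[C@@H](O)[C@@](C)(O)[C@@H]1OC(=O)[C@H](C)[C@@H](O)[C@H](C)[C@@H](O[C@@H]2O[C@H](C)C[C@H](N(C)C)[C@H]2OC(C)=O)[C@@]2(C)C[C@@H](C)[C@H](O2)[C@@H]1C` returns only a limit in this assay, > 100 uM, so no number is known for it; the limit of > 100 uM in this assay, at which 1 of the 2 values shown sits, is all that the data show there, and no step between compound 1 and compound 2 is counted, since they differ in more than one place. Compound 3 `CC[C@H]1OC(=O)O[C@@]1(C)[C@@H]1OC(=O)[C@H](C)C(=O)[C@H](C)[C@@H](O[C@@H]2O[C@H](C)C[C@H](N(C)C)[C@H]2OC(C)=O)[C@@]2(C)C[C@@H](C)[C@H](O2)[C@@H]1C` is compound 1 carrying the change (acetyl in place of hydrogen on an oxygen on a saturated carbon), on an oxygen on a saturated carbon whose other neighbours are a saturated ring carbon, read one bond further out as hydroxy to acetoxy. For the measured compounds named here, no measured step anchors this change. The expectation for the step of a 1.1-fold higher number from compound 1 to compound 3 (0.06 log units; within the scatter) is a small shift within the scatter, with no clear direction. For compound 3 the estimate in this assay is 30 uM, with a range from 10 uM to 100 uM.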

Compound 3, concentration for half-maximal effect: 27.9 uM
For compound 3 the middle estimate is 1.1-fold (0.03 log units) above the measured one; measured number inside the range.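

In this assay, among these compounds, the change from hydroxy to acetoxy reads as a 1.1-fold higher number from compound 1 to compound 3 (0.03 log units; within the scatter) and gives the first measured step at this oxygen on a saturated carbon. For this one pair, the hydrogen on that oxygen can give way to acetyl with no shift beyond the scatter, so the free hydroxy is not required to hold the read-out in this range on the core of compound 1. Nothing in the data shown bears on why the read-out stays within the scatter across this step.

From the compounds shown here alone, whether a benzoyl ester, a methyl ether or an amine at this place would leave the read-out equally unmoved stays open. One step also leaves open whether acetyl on a hydroxy elsewhere on the core of compound 1 would behave the same way.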